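Working notes: chloro in place of bromo

This account rests on a few compounds, and the source may have more. Where it says the series, first, only, none or still open, it means among the compounds named here.

Measured in an ADME assay on J774.A1 cells (Mus musculus) for cytotoxicity, read by MTT assay, with a stated time of 72 h (on this read-out higher numbers stand for lower toxicity in this test and lower numbers for higher toxicity in this test), as follows:
- compound 1 `CC(C)c1ccc(C(Nc2ccc(C3(C)NC(=O)c4ccccc4N3)cc2)c2nnnn2C(C)(C)C)cc1` gives > 400000 nM (a limit)
- compound 2 `CC1(c2ccc(NC(c3ccc(Br)cc3)c3nnnn3C(C)(C)C)cc2)NC(=O)c2ccccc2N1` gives 400000 nM
- compound 3 `COc1cc(-c2cc(-c3ccc(C4NC(=O)c5ccccc5N4)cc3)nc(N)n2)cc(OC)c1OC` gives 103000 nM

Compound 2 at 400000 nM holds the higher of the two actual numbers, and compound 3 at 103000 nM lies lower, beyond the scatter. Compound 1 gives only a limit and takes no place in that order.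

Compound 4 `CC1(c2ccc(NC(c3ccc(Cl)cc3)c3nnnn3C(C)(C)C)cc2)NC(=O)c2ccccc2N1` differs from compound 2 by one change, chloro in place of bromo on an aromatic carbon (chloro in place of bromo on an aromatic carbon, para to a large group). Among the compounds with values here, the one measured step that bears on this change is a number no higher from compound 1 to compound 2 (the limit leaves the size open) (bromo in place of isopropyl on an aromatic carbon), and its size stays open. Within the data shown here, no measured step therefore points to a shift in this assay for this exchange. The estimate is a 1.1-fold lower number from compound 2 to compound 4 (0.06 log units; within the scatter) and so no step beyond the scatter is expected. Also in view is the limit of > 400000 nM in this assay, at which 1 of the 3 values shown sits, and compound 4 may likewise return only a limit. Compound 4 is expected at 350000 nM with an estimated range from 180000 nM to 400000 nM.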

Compound 4, half-maximal cytotoxic concentration: > 400000 nM
Compound 4 was reported as a limit (the forecaster's own chance of this, stated with the estimate: 35%); middle value at least 1.1-fold (0.05 log units) from the limit.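

In this assay compound 4 gives > 400000 nM, which is a limit and not a number. For the 4-bromophenyl to 4-chlorophenyl exchange the record reads a number no lower from compound 2 to compound 4 (the limit leaves the size open), so chloro at this position, like bromo and isopropyl, shows no fall in the number and thus no higher toxicity in this test. The step between compound 1 and compound 4 cannot be read, and the series at this position now presses against the top of the range: the limit of > 400000 nM in this assay, at which 2 of the 4 values shown sit.

Going by these compounds, how far compound 1 and compound 4 lie beyond the limit stays open, so isopropyl and chloro cannot be ranked against each other or against bromo. Also open, on these data alone, is whether an amine or a carboxylic acid on this aromatic carbon would bring the number down to a readable value.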